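A few compounds are considered here, and "the series" means these few. Any claim that something is new, unique, unknown or untested is made for them only; others in the source may bear on it.

In an assay on cell membranes for binding affinity to Fatty-acid amide hydrolase 1 (Rattus norvegicus) (on this read-out higher numbers stand for weaker inhibition and lower numbers for stronger inhibition), compound 3 `CC(=O)c1cccc(-c2cccc(OC(=O)NC3CCCCC3)c2)c1` gives 9.1 nM. Among the three compounds measured so far this is the lowest number: compound 1 `O=C(NC1CCCCC1)Oc1cccc(-c2cccc(OC(=O)NC3CCCCC3)c2)c1` gives 361 nM, and compound 2 `O=C(NC1CCCCC1)Oc1cccc(-c2cccc(Cc3ccccc3)c2)c1` gives 1860 nM. The two steps that lead into compound 3 are both large, a 40-fold lower number from compound 1 to compound 3 (1.60 log units; beyond the scatter) and a 200-fold lower number from compound 2 to compound 3 (2.31 log units; beyond the scatter), while the step between the other two is smaller, a 5.2-fold higher number from compound 1 to compound 2 (0.71 log units; beyond the scatter).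

Compound 4 `N#Cc1cccc(-c2cccc(OC(=O)NC3CCCCC3)c2)c1` keeps the core of compound 3 and differs from it in one place: cyano in place of acetyl on an aromatic carbon. Among the compounds with values here, no measured step exchanges acetyl for cyano, so none bears on this change directly. What the measured steps do show is that the group on this aromatic carbon moves the number a great deal: swapping a (cyclohexylcarbamoyl)oxy group or a benzyl group for acetyl gave the two large steps into compound 3. Both the leaving acetyl and the entering cyano carry one hydrogen-bond acceptor and no ring.

On that basis the analyst expects compound 4 to stay closer to compound 3 than to compound 1, with some loss in this assay, an expected step of a 2.7-fold higher number from compound 3 to compound 4 (0.44 log units; beyond the scatter). The estimate for compound 4 is 25 nM, with a range from 6 nM to 100 nM.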

Compound 4, half-maximal inhibitory concentration: 33.9 nM
Estimate against measurement, compound 4: 1.4-fold (0.13 log units) below; low and high end bracket the measured number.
By their numbers in this assay, from the lowest: compound 3; then compound 4; then compound 1; then compound 2.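

In this assay, within the data shown here, the change from acetyl to cyano is the first exchange on this aromatic carbon in which the entering group is not a (cyclohexylcarbamoyl)oxy or benzyl group, and it gives only a modest step, a 3.7-fold higher number from compound 3 to compound 4 (0.57 log units; beyond the scatter), beyond the scatter but far short of the steps that led into compound 3. The low numbers are therefore not peculiar to acetyl: cyano also gives large steps against the two other groups, an 11-fold lower number from compound 1 to compound 4 (1.03 log units; beyond the scatter), and a 55-fold lower number from compound 2 to compound 4 (1.74 log units; beyond the scatter), so that both acetyl and cyano lie well under the numbers for the (cyclohexylcarbamoyl)oxy and benzyl groups, although acetyl still keeps the lowest number of the four. Nothing available here accounts for the modest difference between acetyl and cyano, or for the large differences from the other two groups.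

The compounds shown leave open whether a primary amide, a carboxylic acid or an amine on this aromatic carbon would stay near compound 3 or fall back toward compound 1. They also leave open how the number would move with a longer chain on the carbonyl, such as propanoyl or butanoyl in place of acetyl.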